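This account rests on a few compounds, and the source may have more. Where it says the series, first, only, none or still open, it means among the compounds named here.

Measured so far in an ADME assay on the whole organism (Rattus norvegicus, strain Sprague-Dawley) for pharmacokinetics, read by LC-MS, with a stated time of 24 h, at a dose of 1 mg/kg by the intravenous route; a lower number here means less compound in the circulation, a higher number more compound in the circulation at the dose given:
compound 1, `CN1CCC(=C(F)c2cccc(NC(=O)c3ccc(F)cn3)n2)CC1`; compound 1 gives 276 nM
compound 2, `CN1CCC(=C(F)c2cccc(NC(=O)c3ccc(Cl)cc3)n2)CC1`; compound 2 gives 170 nM

Going by the values given here, compound 2 holds the lower of the two numbers, but its only neighbour is compound 1, and the step of a 1.6-fold lower number from compound 1 to compound 2 (0.21 log units; within the scatter) stays within the usual scatter, so the two compounds cannot be told apart on these data. Compound 3, `CN1CCC(=C(F)c2cccc(NC(=O)c3ccc(F)cc3)n2)CC1`, has not yet been measured. It differs from compound 2 in one place: fluoro in place of chloro on an aromatic carbon. Among the compounds with values here, only one measured step exists, a 1.6-fold lower number from compound 1 to compound 2 (0.21 log units; within the scatter), and it changed the ring and the halogen together while staying within the scatter; it bears on the present change only in part. The present change is smaller, one halogen for another on the same ring. Compound 3 is therefore expected to show no step beyond the scatter, a 1.1-fold higher number from compound 2 to compound 3 (0.05 log units; within the scatter). The estimate for compound 3 in this assay is 190 nM, with a range from 95 nM to 380 nM.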

Compound 3, maximal plasma concentration: 219 nM
For compound 3 the middle estimate is 1.2-fold (0.06 log units) below the measured one; the range from low to high includes it.
By their numbers in this assay, from the lowest: compounds 2, 3 and 1 (each within the scatter of the next).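

Changing the halogen on this aromatic carbon, para to a large group, gives a 1.3-fold higher number from compound 2 to compound 3 (0.11 log units; within the scatter) and so does not separate chloro from fluoro in this assay. Compound 3 also pulls apart the two changes that were mixed in the earlier comparison: with a fluoro on both rings, going from 5-fluoropyridin-2-yl to 4-fluorophenyl gives a 1.3-fold lower number from compound 1 to compound 3 (0.10 log units; within the scatter) and does not separate those two rings either. No measurement in hand offers a reason for these small differences.

The compounds shown vary only the ring on the carbonyl carbon and its halogen, so it remains open whether a nitrile, a methoxy group or an amine on that same carbon would give a step beyond the scatter. As far as these compounds go, whether a change to the shared core would do so also remains open.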